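The source may report more compounds than this note shows. Statements on the series, on what has been measured and on what is new or still open speak of the compounds shown alone.

Working notes on a two-ring series tested in a functional assay on the whole organism (strain albino) for inhibition, with Rattus norvegicus as the target, read by paw edema, with a stated time of 1 h, at a dose of 20 mmol/kg by the intraperitoneal route; a lower number here means less inhibition, a higher number more inhibition at the dose given (going by the name of the read-out). Compound 1 `CCOC(=O)C(=O)NC1=C(C#N)C2C(N3CCCC3)CCCCN2C(=O)N1c1ccccc1` gives 71.2% in this assay. Among the measured compounds shown here, compound 2 `N#CC1=C(/N=C/Nc2ccccc2)N(c2ccccc2)C(=O)N2CCCCC(N3CCCC3)C12` gives 35.2% in this assay, the lowest of the two numbers so far; its nearest neighbour is compound 1, which sits higher by a step beyond the scatter. For the measured compounds named here, the one measured step shows a number 36 percentage points lower from compound 1 to compound 2 (beyond the scatter), where a group of 9 heavy atoms with one six-membered aromatic ring of carbon only replaces a group of 8 heavy atoms with no ring on a double-bonded ring carbon.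

Compound 3 `COC(=O)C(=O)NC1=C(C#N)C2C(N3CCCC3)CCCCN2C(=O)N1c1ccccc1` is the next compound in this assay. Compared with compound 2 the change is a group of 7 heavy atoms (3 carbon, 1 nitrogen, 3 oxygen; no ring) in place of a group of 9 heavy atoms (7 carbon, 2 nitrogen; one six-membered aromatic ring of carbon only), on a double-bonded ring carbon. The entering ((methoxycarbonyl)carbonyl)amino group, 7 heavy atoms with no ring, sits on the same double-bonded ring carbon of the six-membered non-aromatic ring with 2 nitrogen where the 9-atom group is removed. The step from compound 1 to compound 2 bears on this directly, since the change runs in the reverse direction and the entering group differs from that of compound 1 only in the chain of the ester. A return upward of roughly the same size is therefore expected, so the step from compound 2 to compound 3 is estimated as a number 32.8 percentage points higher from compound 2 to compound 3 (beyond the scatter). Compound 3 is expected to give about 68% in this assay, within 50% to 85%.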

Compound 3, a percentage reported as inhibition, in the whole organism at one dose (the size of the read-out at that dose, not a potency): 69.2%
Compound 3: middle estimate off by 1.2 percentage points, on the low side, within the range that was stated.
By their numbers in this assay, from the lowest: compound 2; then compounds 3 and 1 (each within the scatter of the next).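

In this assay, the ((methoxycarbonyl)carbonyl)amino group on the double-bonded ring carbon brings the read-out back from the level of compound 2, with a number 34 percentage points higher from compound 2 to compound 3 (beyond the scatter), so the large difference at this position now appears in both directions of the exchange with the 9-atom group. The ester chain adds a separate comparison: hydrogen in place of methyl on the saturated chain carbon bound to the oxygen gives a number 2 percentage points lower from compound 1 to compound 3 (within the scatter), so compound 1 and compound 3 cannot be told apart and, among these three compounds, the large differences follow the exchange of the whole group rather than this change in the chain. No measurement at hand accounts for either step.

As far as these compounds go, it remains open whether a free carboxylic acid, a plain amine or a longer ester chain such as butyl on this same carbon would stay level with compound 3 or fall towards compound 2. From the compounds shown here alone, since all three compounds share the rest of the core, it is also open whether these differences would hold with another amine in place of the ring amine on the core.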